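The compounds below may be only part of what the source reports. "The series", "measured", "known", "first", "only" and "open" are said of these compounds alone.

Measured in a functional assay on HeLa cells (Homo sapiens) for antiproliferative activity, read by MTT assay, with a stated time of 72 h; a higher number here means a weaker inhibitor, a lower number a stronger inhibitor:
Compound 1 `COc1cc(-n2ncnc2-c2ccc(Cl)cc2)cc(OC)c1OC`: > 10000 nM
Compound 2 `COc1cc(-n2ncnc2-c2cccc(F)c2)cc(OC)c1OC`: > 10000 nM

Compound 2 gives > 10000 nM, which is a limit of the assay and not a number. Compound 1 gives > 10000 nM, and this too is only a limit. The whole record so far is the limit of > 10000 nM in this assay, at which 2 of the 2 values shown sit. Within the data shown here, the one measured step is a step that the two limits leave unreadable from compound 1 to compound 2, so it offers no size to carry forward.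

Compound 3 `COc1ccccc1-c1ncnn1-c1cc(OC)c(OC)c(OC)c1` keeps the shared core and changes the same aromatic carbon that separates compound 1 and compound 2, on a five-membered aromatic ring with 3 nitrogen. The change is 2-methoxyphenyl in place of 3-fluorophenyl on an aromatic carbon: 2-methoxyphenyl in place of 3-fluorophenyl. Neither measured compound gives a number to start from, so no direction can be argued with confidence, and the reading may again be only a limit. The expected step in this assay is a number no higher from compound 2 to compound 3 (the limit leaves the size open), with no real change foreseen. For compound 3 the estimated value is 10000 nM, with an expected range from 2500 nM to 40000 nM.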

Compound 3, half-maximal inhibitory concentration: > 10000 nM
Compound 3 ended at the assay's limit; the forecaster's own chance of this, stated with the estimate: 70%; the middle value lies on the limit itself.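

In this assay compound 3 gives > 10000 nM, which is a limit of the assay and not a number. The steps to compound 3 from compound 1 and from compound 2 therefore cannot be read. The compounds shown leave open how compound 1, compound 2 and compound 3 truly compare, and which group on this aromatic carbon would give a measurable value: the limit of > 10000 nM in this assay, at which 3 of the 3 values shown sit.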